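Chloro to bromo in a three-compound growth-inhibition series

The compounds below may be only part of what the source reports. "The series", "measured", "known", "first", "only" and "open" are said of these compounds alone.

Within the data shown here, in a functional assay on OVCAR-4 cells (Homo sapiens) for inhibition (on this read-out higher numbers stand for weaker inhibition of growth and lower numbers for stronger inhibition of growth), compound 2 (`Nc1ccc(-c2nc3cc(F)ccc3s2)cc1Cl`) gives 320 nM, the middle number of the three measured so far. Compound 1 (`Nc1ccc(-c2nc3ccc(F)cc3s2)cc1I`), which carries iodo, gives a lower number at 30 nM, and compound 3 (`Nc1ccc(-c2nc3ccccc3s2)cc1C(F)(F)F`), which carries trifluoromethyl, gives a higher one at 15800 nM. Both gaps from compound 2 lie beyond the usual scatter. However, each of these compounds differs from compound 2 in more than one place, and no measured pair isolates a single change.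

Compound 4 (`Nc1ccc(-c2nc3cc(F)ccc3s2)cc1Br`) departs from compound 2 by one exchange: bromo in place of chloro on an aromatic carbon, ortho to an amino group. No measured chloro and bromo pair is available, so the expectation is tentative. Among the measured compounds shown here, it leans toward compound 1 at 30 nM, the only iodo member, and therefore points to a modestly lower number in this assay, a step that may not clear the scatter. The expected step is a 2.1-fold lower number from compound 2 to compound 4 (0.33 log units; beyond the scatter). For compound 4 the estimated value is 150 nM, with an expected range of 30 nM to 700 nM.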

Compound 4, concentration for 50% growth inhibition: 24000 nM
Compound 4: middle estimate off by 160-fold (2.20 log units), on the low side; measured number above the stated range.
By their numbers in this assay, from the lowest: compound 1; then compound 2; then compounds 3 and 4 (each within the scatter of the next).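

In this assay, among these compounds, the exchange of chloro for bromo on an aromatic carbon, ortho to an amino group, gives a 75-fold higher number from compound 2 to compound 4 (1.88 log units; beyond the scatter), and this is the first step that isolates a single change. It shows that this position is highly sensitive to which halogen it carries: the exchange replaces one heavy atom with one heavy atom, leaves the counts of rings, hydrogen-bond donors and acceptors and the net charge unchanged, and still produces a large loss of growth inhibition. No evidence in hand bears on the origin of so large a step.

Whether the step is specific to the core of compound 2 remains open, since no chloro and bromo pair is shown on the core of compound 1 or compound 3, and the iodo of compound 1 has no partner that differs from it in one place. A hydrogen, methyl, methoxy or nitrile at this position on the core of compound 2 would show whether chloro is unusually favourable or bromo unusually unfavourable here.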